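The compounds below may be only part of what the source reports. "The series", "measured", "known", "first", "only" and "open" are said of these compounds alone.

Compound 1 `Cn1c(=O)c2nc(-c3ccc(Cl)cc3)[nH]c2n(C)c1=O` is the reference point of this small set. In an assay for binding affinity to adenosine receptor A1 (Bos taurus) (a lower number here means a stronger inhibitor, a higher number a weaker inhibitor), compound 1 gives 0.8 nM, the highest of the three numbers recorded so far. Compound 2 `CCCn1c(=O)c2nc(-c3ccccc3N)[nH]c2n(CCC)c1=O` sits within the scatter of it, giving 0.75 nM in this assay. Going by the values given here, compound 3 `Cn1c(=O)c2nc(-c3ccc(Cl)cc3N)[nH]c2n(C)c1=O` is the one that separates itself: it gives 0.35 nM in this assay, and the only single-point step in the set, a 2.3-fold lower number from compound 1 to compound 3 (0.36 log units; beyond the scatter), came from adding an amino group on an aromatic carbon of the same shared core.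

Compound 4 `CCOc1ccc(-c2nc3c(=O)n(C)c(=O)n(C)c3[nH]2)cc1` changes a different position. The difference from compound 1 is ethoxy in place of chloro on an aromatic carbon. Among the compounds with values here, no measured step touches this position; the amino step from compound 1 to compound 3 concerns another carbon of the ring, and compound 2 differs from compound 1 in several places at once, so nothing recorded here speaks directly to swapping one group for another at the place para to the large group. With no guide, the reasonable expectation is that compound 4 stays near compound 1, and the estimated step is a 1.9-fold higher number from compound 1 to compound 4 (0.27 log units; within the scatter). For compound 4 in this assay the estimate is 1.5 nM, with a range from 0.4 nM to 6 nM.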

Compound 4, half-maximal inhibitory concentration: 2 nM
The estimate for compound 4 lay 1.3-fold (0.12 log units) below the measured number, and the stated range covers the measured number.
By their numbers in this assay, from the lowest: compound 3; then compounds 2 and 1 (each within the scatter of the next); then compound 4.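

In this assay, going by these compounds alone, the step from chloro to ethoxy on an aromatic carbon para to a large group gives a 2.5-fold higher number from compound 1 to compound 4 (0.40 log units; beyond the scatter), the first measured step at this position and one beyond the scatter. It runs in the opposite direction to the amino step at another carbon of the ring, a 2.3-fold lower number from compound 1 to compound 3 (0.36 log units; beyond the scatter), so the two single-point changes in this set do not move the number the same way. The change replaces one heavy atom with three and brings in a hydrogen-bond acceptor, but nothing measured here separates the loss of chloro from the gain of either the ethoxy chain or its oxygen, and no outside measurement bears on the result.

The compounds shown leave open whether methoxy, a longer chain such as butoxy, or an amine at this place would give a number closer to that of compound 1 or further from it. They also leave open whether ethoxy in place of chloro would give a step of similar size on compound 3, which carries the amino group.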